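The source may report more compounds than this note shows. Statements on the series, on what has been measured and on what is new or still open speak of the compounds shown alone.

In a functional assay on L1210 cells (Mus musculus) for antiproliferative activity, with a stated time of 48 h (a lower number here means a stronger inhibitor, a higher number a weaker inhibitor), three compounds have been measured:
compound 1 `C=C(Br)C(=O)Nc1ccc(C(=O)/C=C/c2ccc(OC)cc2)cc1`: 900 nM
compound 2 `C=C(Br)C(=O)Nc1ccc(C(=O)/C=C/c2ccc(OC)cc2OC)cc1`: 520 nM
compound 3 `C=C(Br)C(=O)Nc1ccc(C(=O)/C=C/c2ccc(OC)c(OC)c2OC)cc1`: 630 nM

The value of compound 2 lies within the scatter of both others. Compound 4 `COc1ccc(/C=C/C(=O)c2ccc(N)cc2)c(OC)c1` differs from compound 2 as follows: hydrogen in place of (1-bromoethenyl)carbonyl on a nitrogen on an aromatic ring. It has hydrogen in place of (1-bromoethenyl)carbonyl on a nitrogen on an aromatic ring. Going by the values given here, no measured step touches this group. The two available steps, a 1.7-fold lower number from compound 1 to compound 2 (0.24 log units; within the scatter) and a 1.2-fold higher number from compound 2 to compound 3 (0.08 log units; within the scatter), each exchange hydrogen for methoxy, so they bear on it only indirectly. Among the compounds with values here, the change here is much larger, and the data contain no compound without the group, so a step to a higher number beyond the scatter is expected, though its size is poorly constrained. The estimate means a 13-fold higher number from compound 2 to compound 4 (1.13 log units; beyond the scatter), an expected loss of activity in this assay. For compound 4 the estimated value is 7000 nM, with an expected range from 1800 nM to 28000 nM.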

Compound 4, half-maximal inhibitory concentration: 34000 nM
Compound 4: the middle estimate sits 4.9-fold (0.69 log units) below what was measured, outside the stated range (above it).
By their numbers in this assay, from the lowest: compounds 2, 3 and 1 (each within the scatter of the next); then compound 4.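

In this assay, going by these compounds alone, hydrogen in place of (1-bromoethenyl)carbonyl on the nitrogen gives a 65-fold higher number from compound 2 to compound 4 (1.82 log units; beyond the scatter) and takes compound 4 beyond the scatter of the earlier compounds, whose methoxy steps stayed within it. The number in this series therefore responds strongly to this position, which the methoxy exchanges on the other aromatic ring could not show. No measurement shown explains this step. The compounds shown leave open whether the step belongs to the bromine or to the whole group on the nitrogen. An acetyl or (1-chloroethenyl)carbonyl group at this place would separate the two.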